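The source may hold more compounds than are shown below. What is called first, only, known or untested is meant among the compounds shown, and "the series" means these compounds.

Measured in a physicochemical assay for lipophilicity, at pH 7.4; a higher number here means a more lipophilic compound, a lower number a more polar compound:
- compound 1 `CNC(=O)c1cc(C(=O)NC2CC2)cn(Cc2cccc(F)c2)c1=O`: 3.2
- compound 2 `CNC(=O)c1cc(C(=O)NC2CC2)cn([C@H](C)c2ccccc2)c1=O`: 3.4
- compound 3 `CNC(=O)c1cc(C(=O)NC2CC2)cn(Cc2nccc3[nH]ccc23)c1=O`: 1.7

Compound 3 has the lowest number of the three, and both other compounds lie beyond the scatter from it. Compound 4 `CNC(=O)c1cc(C(=O)NC2CC2)cn(CC2CCCOC2)c1=O` differs from compound 3 by a group of 6 heavy atoms (5 carbon, 1 oxygen; one six-membered non-aromatic ring with 1 hetero atom) in place of a group of 9 heavy atoms (7 carbon, 2 nitrogen; one five-membered aromatic ring with 1 hetero atom, one six-membered aromatic ring with 1 hetero atom), on a saturated chain carbon bound to an aromatic nitrogen. The group that enters is oxan-3-yl, and the group that leaves has no common name.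

Going by the values given here, two measured steps concern this same part of the structure. The first, a number 0.20 log units higher from compound 1 to compound 2 (within the scatter), is small. The second, a number 1.50 log units lower from compound 1 to compound 3 (beyond the scatter), is large and shows that a change of group here can move the number well beyond the scatter. Neither step involves an oxan-3-yl group or any other non-aromatic ring, so they give only a rough guide. The span seen so far runs from compound 3 at 1.7 to compound 2 at 3.4, and compound 4 is expected to fall in its lower part.

The expected change is a small rise, a number 0.30 log units higher from compound 3 to compound 4 (within the scatter), and it is not expected to lie beyond the scatter. For compound 4 the estimate in this assay is 2, with an expected range of 1.5 to 2.6.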

Compound 4, distribution coefficient: 2
Estimate against measurement, compound 4: no gap at the digits printed, within the range that was stated.
By their numbers in this assay, from the lowest: compounds 3 and 4 (each within the scatter of the next); then compounds 1 and 2 (each within the scatter of the next).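

In this assay, the step of a number 0.30 log units higher from compound 3 to compound 4 (within the scatter) shows that oxan-3-yl, the only non-aromatic ring at this place on the saturated chain carbon, stands level with the group of compound 3, even though the two groups differ in ring type and only the leaving group carries a hydrogen-bond donor; among these compounds, then, a number at this low level needs neither an aromatic ring nor a hydrogen-bond donor in this group. The steps of a number 1.20 log units lower from compound 1 to compound 4 (beyond the scatter) and a number 1.40 log units lower from compound 2 to compound 4 (beyond the scatter) are both large, so the separation of compounds 3 and 4 from compounds 1 and 2 now rests on two quite different groups rather than on compound 3 alone. No measurement at hand accounts for the size of these steps, so the result stands as an observation only.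

Open, on these data alone, is how far the ring oxygen of oxan-3-yl matters, which cyclohexyl on the same saturated chain carbon would help to settle. Also open, as far as these compounds go, is where an amine such as piperidin-3-yl, a carboxylic acid or an open 2-methoxyethyl chain would fall.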